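The compounds below may be only part of what the source reports. "The series", "measured", "known", "first", "only" and "open" are said of these compounds alone.

Compound 1 `CN(C)c1ccc(C2CC(c3ccc(-n4cncn4)cc3)=NN2C(=O)c2ccc(F)cc2)cc1` carries a (4-fluorophenyl)carbonyl group on the ring nitrogen of the shared core. In a functional assay on NCI-H1975 cells (Homo sapiens) for inhibition, read by sulforhodamine B assay, tested at 10 uM (on this read-out higher numbers stand for more inhibition at the one concentration tested (going by the name of the read-out) and lower numbers for less inhibition), compound 1 gives -1.1%, which means essentially no inhibition at the concentration tested. Compound 2 `CN(C)c1ccc(C2CC(c3ccc(-n4cncn4)cc3)=NN2S(C)(=O)=O)cc1` replaces that group with a methylsulfonyl; in this assay compound 2 gives -3.1%. The step of a number 2 percentage points lower from compound 1 to compound 2 (within the scatter) shows the two compounds sitting together, neither one inhibiting the cells. Among the compounds with values here, compound 2 therefore stands next to compound 1, the only other measured compound, with nothing separating them beyond the scatter.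

Compound 3 `CN(C)c1ccc(C2CC(c3ccc(-n4cncn4)cc3)=NN2S(=O)(=O)c2ccc(C#N)cc2)cc1` is the next step from compound 2: 4-cyanophenyl in place of methyl on a sulfonyl sulfur. Within the data shown here, the one measured step, from compound 1 to compound 2, already moved an aromatic ring on or off this same ring nitrogen without any change beyond the scatter, so it offers no sign that adding a ring back, now on the sulfonyl sulfur, would matter. The expected step is a number 2.1 percentage points higher from compound 2 to compound 3 (within the scatter), no movement beyond the scatter. Compound 3 is thus estimated to give -1% in this assay, within -14% to 14%.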

Compound 3, a percentage reported as inhibition, at one concentration (the size of the read-out at that concentration, not a potency): 22.6%
The estimate for compound 3 lay 23.6 percentage points below the measured number; the whole stated range lies below it.
By their numbers in this assay, from the lowest: compounds 2 and 1 (each within the scatter of the next); then compound 3.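

In this assay, within the data shown here, the group on the sulfonyl sulfur turns out to matter: 4-cyanophenyl in place of methyl brings a number 25.7 percentage points higher from compound 2 to compound 3 (beyond the scatter), the first step in this small set to go beyond the scatter. The comparison with the carbonyl compound points the same way, since (4-cyanophenyl)sulfonyl in place of (4-fluorophenyl)carbonyl on the ring nitrogen brings a number 23.7 percentage points higher from compound 1 to compound 3 (beyond the scatter), which shows that carrying an aromatic ring at this place is not enough by itself, as compound 1 also has one and stays within the scatter of compound 2. No measurement available here gives a reason for either step.

The ring and the nitrile enter together in compound 3, so the compounds shown leave open whether the gain comes from the sulfonyl-linked ring, from the nitrile, or from the two combined. A plain phenyl on the sulfonyl sulfur would help separate these, and a (4-cyanophenyl)carbonyl group on the ring nitrogen would show whether the sulfonyl link is needed at all.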